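The source may hold more compounds than are shown below. What is called first, only, known or untested is meant among the compounds shown, and "the series" means these compounds.

Measured compounds:
Compound 1 `CC(C)(C)OC(=O)N1CCC2(CC1)CC(CCCOc1ccc(S(C)(=O)=O)c(F)c1)C2`: 9 nM
Compound 2 `CC(C)OC(=O)N1CCC2(CC1)CC(CCCOc1ccc(C(N)=O)c(F)c1)C2`: 52 nM

In a functional assay on cells for agonist activity at Glucose-dependent insulinotropic receptor (Homo sapiens), read by HTRF and cAMP accumulation, with a stated time of 30 min (on this read-out higher numbers stand for an effect only at larger amounts of compound and lower numbers for an effect already at smaller amounts), compound 2 gives 52 nM, the higher of the two numbers; compound 1 sits at a lower number, and that gap lies beyond the scatter. Compound 3 `CC(C)OC(=O)N1CCC2(CC1)CC(CCCOc1ccc(C(=O)NCC(N)=O)c(F)c1)C2` has not yet been measured. It differs from compound 2 in one place: carbamoylmethyl in place of hydrogen on an amide-type nitrogen. Within the data shown here, no measured pair shows this change, so its size is open. A modest step towards a higher number is expected, a 1.5-fold higher number from compound 2 to compound 3 (0.19 log units; within the scatter), though a shift within the scatter would not surprise. Compound 3 is therefore estimated at about 80 nM, with a likely range from 25 nM to 300 nM.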

Compound 3, half-maximal effective concentration: 48 nM
Compound 3: the middle estimate sits 1.7-fold (0.22 log units) above what was measured; the measured number falls inside the stated range.
By their numbers in this assay, from the lowest: compound 1; then compounds 3 and 2 (each within the scatter of the next).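

The step of a 1.1-fold lower number from compound 2 to compound 3 (0.03 log units; within the scatter) comes with carbamoylmethyl in place of hydrogen on the amide-type nitrogen, read in this assay. Among these compounds, this nitrogen therefore takes a group of 4 heavy atoms with no shift that can be told from the scatter, which no earlier pair could show. Nothing measured here speaks to why the number holds.

From the compounds shown here alone, whether a longer chain ending in the same carbamoyl, or a carboxylic acid or an amine in place of that carbamoyl, would also leave the number within the scatter remains open.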